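The compounds below may be only part of what the source reports. "The series", "measured", "known", "first", "only" and "open" are said of these compounds alone.

Compound 2 `COC(=O)C(=N)/C=C(\O)c1ccc(Cl)cc1` stands highest of the three compounds measured in an assay for inhibition of kynurenine 3-monooxygenase (Rattus norvegicus), tested at 10 uM (on this read-out higher numbers stand for more inhibition at the one concentration tested (going by the name of the read-out) and lower numbers for less inhibition), where compound 2 gives 13%. Its nearest neighbour is compound 1 `COC(=O)C(=N)/C=C(\O)c1ccccc1`, which in this assay gives 3%; the step between them was a number 10 percentage points higher from compound 1 to compound 2 (within the scatter). Compound 3 `COC(=O)C(=N)/C=C(\O)c1ccc(F)cc1` lies furthest away: in this assay compound 3 gives 1%, and the step was a number 12 percentage points lower from compound 2 to compound 3 (beyond the scatter). The remaining pair shows a number 2 percentage points lower from compound 1 to compound 3 (within the scatter).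

The unmeasured compound 4 `COC(=O)C(=N)/C=C(\O)c1ccc(Cl)c(Cl)c1` arises from compound 2 by a change counted as chloro in place of hydrogen on an aromatic carbon. Within the data shown here, the only measured step that bears directly on it, likewise a chloro in place of hydrogen on an aromatic carbon, was a number 10 percentage points higher from compound 1 to compound 2 (within the scatter). The two steps that involve fluoro give no guide to what a second chloro will do. A second chloro on the same ring is therefore expected to nudge the read-out in this assay only slightly upward, if at all, and the expected step is a number 5 percentage points higher from compound 2 to compound 4 (within the scatter). For compound 4 the estimated inhibition in this assay is 18%, with an expected range from 5% to 35%.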

Compound 4, a percentage reported as inhibition, at one concentration (the size of the read-out at that concentration, not a potency): 37%
Beside the measured number, compound 4's estimate is 19 percentage points below it, outside the stated range (above it).
By their numbers in this assay, from the lowest: compounds 3, 1 and 2 (each within the scatter of the next, the first and the last beyond it); then compound 4.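

In this assay, chloro in place of hydrogen on an aromatic carbon, ortho to a chloro group and meta to a group of 9 heavy atoms, gave a number 24 percentage points higher from compound 2 to compound 4 (beyond the scatter). Among these compounds, this is the first chloro-for-hydrogen change whose step lies beyond the scatter, whereas the earlier one, a number 10 percentage points higher from compound 1 to compound 2 (within the scatter), stayed within it, so the same counted change does not carry a single size across these compounds, and at this position, on a ring that already holds a chloro, the printed step is the larger of the two. No measurement is available here that would explain this step.

The compounds shown leave open whether chloro at this position would give a similar step without the chloro group already on the ring, and whether a bromo, a methyl or a methoxy group there would do the same. They also leave open how the read-out would respond with a carboxylic acid or an amide in place of the ester of the shared core, and what potency lies behind these single-concentration numbers.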